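Swapping 4-(methylsulfonyl)phenyl for 1-benzothiophen-5-yl

This account rests on a few compounds, and the source may have more. Where it says the series, first, only, none or still open, it means among the compounds named here.

Compound 1 `CCn1cc(-c2cc(C(O)(C(F)(F)F)C(F)(F)F)cnc2N2CCN(S(=O)(=O)c3ccc(N)nc3)CC2)cn1`: 20 mL.min-1.g-1
Compound 2 `CS(=O)(=O)c1ccc(-c2cc(C(O)(C(F)(F)F)C(F)(F)F)cnc2N2CCN(S(=O)(=O)c3ccc(N)nc3)CC2)cc1`: 32 mL.min-1.g-1

In an ADME assay (liver) for metabolic stability, with Liver microsome (Homo sapiens) as the target, using microsomes and NADPH, with a stated time of 30 min, tested at 1 uM (a lower number here means slower removal, a higher number faster removal of the compound), compound 2 gives 32 mL.min-1.g-1, which lies within the usual scatter of compound 1, so the two cannot be ranked. Compound 3 `Nc1ccc(S(=O)(=O)N2CCN(c3ncc(C(O)(C(F)(F)F)C(F)(F)F)cc3-c3ccc4sccc4c3)CC2)cn1` carries 1-benzothiophen-5-yl in place of 4-(methylsulfonyl)phenyl on an aromatic carbon. Going by the values given here, the only measured step at this place, a 1.6-fold higher number from compound 1 to compound 2 (0.20 log units; within the scatter), stays within the scatter. It involves a different pair of groups, however, so it bounds the new change only loosely. Among the compounds with values here, no measurement yet shows how 1-benzothiophen-5-yl behaves here, and the expected direction is therefore a judgement with a wide margin. A modest rise is expected, a 1.6-fold higher number from compound 2 to compound 3 (0.19 log units; within the scatter). For compound 3 the estimated value is 50 mL.min-1.g-1, with an expected range of 22 mL.min-1.g-1 to 110 mL.min-1.g-1.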

Compound 3, intrinsic clearance in microsomes: 48 mL.min-1.g-1
Estimate against measurement, compound 3: 1.0-fold (0.02 log units) above; the measured number falls inside the stated range.
By their numbers in this assay, from the lowest: compounds 1, 2 and 3 (each within the scatter of the next, the first and the last beyond it).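

In this assay, the change from 4-(methylsulfonyl)phenyl to 1-benzothiophen-5-yl gives a 1.5-fold higher number from compound 2 to compound 3 (0.18 log units; within the scatter), so these two groups cannot be ranked at this position. Going by these compounds alone, the wider comparison gives the first step at this position to pass the scatter, a 2.4-fold higher number from compound 1 to compound 3 (0.38 log units; beyond the scatter), and so shows that the group on this aromatic carbon can shift intrinsic clearance in microsomes, though only modestly, with 1-ethyl-1H-pyrazol-4-yl giving the lower number and 1-benzothiophen-5-yl the higher. No supporting data here account for this difference. The compounds shown leave open how an amine or a carboxylic acid on this aromatic carbon would read in this assay. They also leave open whether any group at this place could bring the number clearly below that of compound 1.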